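Replacing a methylbenzyl ether with a methoxybenzyl ether

This account rests on a few compounds, and the source may have more. Where it says the series, first, only, none or still open, it means among the compounds named here.

Among the three compounds measured in an ADME assay on Huh-5-2 cells (Homo sapiens) for cytotoxicity, read by WST assay, with a stated time of 3 days (a lower number here means that less compound is tolerated, a higher number that more compound is tolerated), compound 2 `Cc1ccccc1COc1cc(O)c2c(=O)c(O)c(-c3ccccc3)oc2c1` is the only one to give a number, 17000 nM. Compound 1 `O=c1c(O)c(-c2ccccc2)oc2cc(OCc3ccccc3Br)cc(O)c12` reaches only a limit there, > 100000 nM. Compound 3 `COc1ccccc1COc1cc(O)c2c(=O)c(O)c(-c3ccccc3)oc2c1` likewise stops at a limit, > 100000 nM. Compound 4 `COc1cccc(COc2cc(O)c3c(=O)c(O)c(-c4ccccc4)oc3c2)c1` has not been measured; it differs from compound 2 by 3-methoxyphenyl in place of 2-methylphenyl on a saturated chain carbon bound to an oxygen on an aromatic ring. Among the compounds with values here, the nearest measured step is an at least 5.8-fold higher number from compound 2 to compound 3 (0.76 log units; beyond the scatter), and an at least 5.8-fold lower number from compound 1 to compound 2 (0.76 log units; beyond the scatter) points the same way: compound 2 with its methyl carries the only finite number, while both of its neighbours sit at the limit of > 100000 nM in this assay, at which 2 of the 3 values shown sit. An exchange of methyl for methoxy, here read as 2-methylbenzyl to 3-methoxybenzyl, is therefore expected to move compound 4 upward in this assay by a 4.7-fold higher number from compound 2 to compound 4 (0.67 log units; beyond the scatter), so compound 4 is estimated at 80000 nM, within 20000 nM to 300000 nM.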

Compound 4, half-maximal cytotoxic concentration: > 100000 nM
Compound 4 ended at the assay's limit; the forecaster's own chance of this, stated with the estimate: 60%; middle value at least 1.2-fold (0.09 log units) away from the limit.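

The step to 3-methoxyphenyl is an at least 5.8-fold higher number from compound 2 to compound 4 (0.76 log units; beyond the scatter) in this assay, so the higher reading seen with 2-methoxyphenyl in compound 3 also appears with the methoxy group in the 3-methoxyphenyl form. The result for compound 4 is a limit, not a number, and the steps among compound 1, compound 3 and compound 4 cannot be read. Compound 2 remains the only compound with a number, and the others share one limit: the limit of > 100000 nM in this assay, at which 3 of the 4 values shown sit.

Going by these compounds, whether 3-methylphenyl would behave like 2-methylphenyl remains open. So does the outcome with an amine or a carboxylic acid on this ring.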